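The compounds below may be only part of what the source reports. "The series", "measured", "known", "first", "only" and "open" are said of these compounds alone.

Of the compounds shown here, three with a shared core have been measured in an assay on IMR-32 cells for displacement of a labelled ligand from corticotropin-releasing factor receptor 1 (Homo sapiens), read by scintillation counting, with a stated time of 2 h; on this read-out higher numbers stand for weaker inhibition and lower numbers for stronger inhibition. Compound 1 `CCc1nc(NC(CC)CC)c(Cl)nc1-c1ccc(Cl)cc1Cl` gives 71 nM. Compound 2 `CCc1nc(NC(CC)CC)cnc1-c1ccc(Cl)cc1Cl` gives 545 nM. Compound 3 `CCc1nc(-c2ccc(Cl)cc2Cl)c(CC)nc1NC(COC)COC` gives 224 nM, which places compound 3 second highest of the three numbers: closest to compound 2 and furthest from compound 1, with both gaps lying beyond the scatter.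

Within the data shown here, the one step recorded between measured compounds is a 7.7-fold higher number from compound 1 to compound 2 (0.89 log units; beyond the scatter), a change of hydrogen in place of chloro on an aromatic carbon of the core. Compound 4 `CCCN(CCN(C)C)c1nc(CC)c(-c2ccc(Cl)cc2Cl)nc1CC` arises from compound 3 by a different kind of change, ((2-(dimethylamino)ethyl)(propyl)amino in place of (2-methoxy-1-(methoxymethyl)ethyl)amino on an aromatic carbon). Among the measured compounds shown here, the chloro-to-hydrogen step does not touch the amine substituent, so no measured step tracks the change from compound 3 to compound 4, and the direction of its effect cannot be read from the data at hand.

On that basis compound 4 is expected to stay close to compound 3, with a step of a 1.5-fold lower number from compound 3 to compound 4 (0.17 log units; within the scatter) that may well remain within the scatter. The estimate for compound 4 in this assay is therefore 150 nM, with a range from 40 nM to 600 nM.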

Compound 4, inhibition constant: 1540 nM
For compound 4 the middle estimate is 10-fold (1.01 log units) below the measured one, and the stated range ends below it.
By their numbers in this assay, from the lowest: compound 1; then compound 3; then compound 2; then compound 4.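

In this assay, putting (2-(dimethylamino)ethyl)(propyl)amino in place of (2-methoxy-1-(methoxymethyl)ethyl)amino gives a 6.9-fold higher number from compound 3 to compound 4 (0.84 log units; beyond the scatter), the first measured sign that inhibition at this aromatic carbon depends on the amine group it carries. This single replacement changes several features at once: the 1 hydrogen-bond donor of the group that leaves becomes 0 hydrogen-bond donors in the group that enters, both oxygen atoms are lost, and a second nitrogen appears, so the step cannot be assigned to any one of them. Nothing available explains why inhibition weakens with this change.

The compounds shown leave open whether the weaker inhibition follows from the dimethylamino end of the chain, the propyl group on the linking nitrogen, or the loss of the methoxy groups. A (2-methoxyethyl)(propyl)amino group or a dipropylamino group on the same carbon of the shared core would help separate these parts, as each keeps some features of the two groups compared here.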